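A few compounds are considered here, and "the series" means these few. Any claim that something is new, unique, unknown or untested is made for them only; others in the source may bear on it.

Measured compounds:

- compound 1, `O=c1oc2ccc(Cl)cc2cc1-c1cn2nc(-c3c([O-])[o+]nn3-c3ccc(Cl)cc3)sc2n1`: in a functional assay on HT-29 cells (Homo sapiens) for cytotoxicity, read by sulforhodamine B assay (a higher number here means a weaker inhibitor of growth, a lower number a stronger inhibitor of growth), compound 1 gives 8 ug/mL
- compound 2, `O=c1oc2ccc(Cl)cc2cc1-c1cn2nc(-c3c([O-])[o+]nn3-c3ccccc3)sc2n1`: in this assay compound 2 gives 7.7 ug/mL

Within the data shown here, compound 2 holds the lowest of the two numbers in this assay, but its only neighbour, compound 1, sits so close that the pair cannot be ordered: a 1.0-fold lower number from compound 1 to compound 2 (0.02 log units; within the scatter). Among the measured compounds shown here, that step, hydrogen in place of chloro on an aromatic carbon, is the only measured step in the set.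

Compound 3, `O=c1oc2ccc(Br)cc2cc1-c1cn2nc(-c3c([O-])[o+]nn3-c3ccccc3)sc2n1`, is not yet measured. It differs from compound 2 by bromo in place of chloro on an aromatic carbon. For the measured compounds named here, no measured step exchanges one halogen for another on this ring, so nothing directly bears on the change. Going by the values given here, the one step that is known, a 1.0-fold lower number from compound 1 to compound 2 (0.02 log units; within the scatter), touches a halogen on the other ring and stays within the scatter. On that basis the expectation for compound 3 in this assay is no step beyond the scatter: a 1.0-fold lower number from compound 2 to compound 3 (0.01 log units; within the scatter). Compound 3 is therefore estimated at 7.5 ug/mL, with a range from 4 ug/mL to 15 ug/mL.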

Compound 3, concentration for 50% growth inhibition: 5.6 ug/mL
The estimate for compound 3 lay 1.3-fold (0.13 log units) above the measured number; the range from low to high includes it.
By their numbers in this assay, from the lowest: compounds 3, 2 and 1 (each within the scatter of the next).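

Compounds 1 and 2 only gave a reading for a halogen on the other ring. Among these compounds, compound 3 adds the first reading at this position, on an aromatic carbon of a six-membered aromatic ring of carbon only, part of a fused or bridged system of two rings: in this assay, bromo in place of chloro gives a 1.4-fold lower number from compound 2 to compound 3 (0.14 log units; within the scatter). Exchanging one halogen for another here therefore leaves the read-out within the scatter, as does hydrogen in place of chloro on the other ring, a 1.0-fold lower number from compound 1 to compound 2 (0.02 log units; within the scatter), so neither of the two measured single changes separates its pair. No measured evidence on hand bears on this result.

The compounds shown have only chloro or bromo at this position, so they leave open whether hydrogen, an amine, a methoxy group or a carboxylic acid there would also stay within the scatter. They also leave open whether the bromo and chloro pair would stay this close with another group on the other ring, such as methoxy or nitrile, in place of the hydrogen of compound 2 and compound 3.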